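Swapping the 4-methylpiperazin-1-yl amide for 4-hydroxypiperidin-1-yl

The source may report more compounds than this note shows. Statements on the series, on what has been measured and on what is new or still open speak of the compounds shown alone.

For the measured compounds named here, in a functional assay on A20 cells (Mus musculus) for inhibition, with stated times of 1 h, 16 h and 24 h (on this read-out higher numbers stand for weaker inhibition and lower numbers for stronger inhibition), compound 1 (`CC1CCN(C(=O)[C@@H]2C[C@H](S(=O)(=O)c3ccccc3)C[C@H]2C(=O)NC2(C#N)CC2)CC1`) gives 2 nM, and compound 2 (`CN1CCN(C(=O)[C@@H]2C[C@H](S(=O)(=O)c3ccccc3)C[C@H]2C(=O)NC2(C#N)CC2)CC1`) gives 17 nM, the higher of the only two numbers available. Compound 3 (`N#CC1(NC(=O)[C@@H]2C[C@@H](S(=O)(=O)c3ccccc3)C[C@H]2C(=O)N2CCC(O)CC2)CC1`) is not yet measured and departs from compound 2 by 4-hydroxypiperidin-1-yl in place of 4-methylpiperazin-1-yl on a carbonyl carbon. Going by the values given here, one measured step bears on this: an 8.5-fold higher number from compound 1 to compound 2 (0.93 log units; beyond the scatter), a change at the same carbonyl carbon that lies beyond the scatter. Among the compounds with values here, the entering group has a six-membered non-aromatic ring with 1 hetero atom, as the 4-methylpiperidin-1-yl of compound 1 does, but no compound with a hydroxy group has been measured. A partial move toward compound 1 at 2 nM is therefore expected, not a full return. The expected change is a 1.9-fold lower number from compound 2 to compound 3 (0.28 log units; within the scatter), a small shift toward a lower number that may not clear the scatter. Compound 3 is estimated at 9 nM, with an expected range of 3 nM to 30 nM.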

Compound 3, half-maximal inhibitory concentration: 371 nM
For compound 3 the middle estimate is 41-fold (1.62 log units) below the measured one; measured number outside the range, above it.
By their numbers in this assay, from the lowest: compound 1; then compound 2; then compound 3.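

In this assay, the group on this carbonyl carbon turns out to be far more sensitive than an 8.5-fold higher number from compound 1 to compound 2 (0.93 log units; beyond the scatter) alone could show: a 190-fold higher number from compound 1 to compound 3 (2.27 log units; beyond the scatter) follows from hydroxy in place of methyl on a saturated ring carbon, with the ring itself unchanged. Ring type does not set the order in these three compounds, since compound 3 shares its six-membered non-aromatic ring with 1 hetero atom with compound 1, yet a 22-fold higher number from compound 2 to compound 3 (1.34 log units; beyond the scatter) puts it on the far side of compound 2, whose ring has 2 hetero atoms. No measurement at hand gives a reason for the loss seen with the hydroxy group.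

The compounds shown leave open whether the loss belongs to the hydroxy group alone or would extend to a methoxy group, a fluorine atom or an amino group on the same ring carbon. They also leave open where a plain piperidin-1-yl amide, with neither methyl nor hydroxy, would fall relative to compound 1 and compound 3, which would show whether the methyl group of compound 1 adds to inhibition or the hydroxy group takes away from it.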